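Cyclohexenylmethyl swap carried onto the long-chain ester

The source may hold more compounds than are shown below. What is called first, only, known or untested is meant among the compounds shown, and "the series" means these compounds.

Compound 1 `CCCC(=O)OC[C@H]1O[C@H](CC2=CCCCC2)C=CC1=O`, compound 3 `CCCC(=O)OC[C@H]1O[C@H](C2CCCC=C2C)C=CC1=O` and compound 2 `CC/C=C\C/C=C\C/C=C\C/C=C\C/C=C\C/C=C\CCC(=O)OC[C@H]1O[C@H](C2CCCC=C2C)C=CC1=O` have been measured in a functional assay on LFCl2A cells (Rattus norvegicus) for cytotoxicity; on this read-out higher numbers stand for weaker inhibition and lower numbers for stronger inhibition. Compound 1 gives 90 nM in this assay, compound 3 gives 350 nM, and compound 2 gives 20 nM, the lowest of the three. The difference between the cores of compound 2 and compound 3 is not broken down here. The change from compound 3 to compound 1 is (cyclohex-1-en-1-yl)methyl in place of 2-methylcyclohex-2-en-1-yl on a saturated ring carbon, and it made a step of a 3.9-fold lower number from compound 3 to compound 1 (0.59 log units; beyond the scatter). Compound 4 `CC/C=C\C/C=C\C/C=C\C/C=C\C/C=C\C/C=C\CCC(=O)OC[C@H]1O[C@H](CC2=CCCCC2)C=CC1=O` arises from compound 2 by the same kind of change, ((cyclohex-1-en-1-yl)methyl in place of 2-methylcyclohex-2-en-1-yl on a saturated ring carbon); the surroundings differ in that the ring atom two ring bonds from the place bears a large group in compound 2 but a ((propylcarbonyl)oxy)methyl group in compound 3. Among the measured compounds shown here, compound 4 is expected to move by about a 3.3-fold lower number from compound 2 to compound 4 (0.52 log units; beyond the scatter), resting on the single earlier step of a 3.9-fold lower number from compound 3 to compound 1 (0.59 log units; beyond the scatter). The estimate for compound 4 in this assay is 6 nM, between 2 nM and 20 nM.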

Compound 4, half-maximal inhibitory concentration: 50 nM
Compound 4: middle estimate off by 8.3-fold (0.92 log units), on the low side; the whole stated range lies below it.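

In this assay the change gives a 2.5-fold higher number from compound 2 to compound 4 (0.40 log units; beyond the scatter), opposite in direction to the step on the other core. The swap therefore does not carry between these two cores as a constant shift: the same change on two cores in this assay, a 3.9-fold lower number (0.59 log units; beyond the scatter) from compound 3 to compound 1 and a 2.5-fold higher number (0.40 log units; beyond the scatter) from compound 2 to compound 4, 9.7-fold (0.99 log units) apart, beyond the scatter of two such steps. This rests on one pair per core, and it does not show why the direction reverses or how the change behaves on any other ester.

The compounds shown leave open whether the reversal tracks the length of the ester chain, which an octanoyl ester carrying each of the two cyclohexene groups would test. They also leave open how either cyclohexene group behaves with a free hydroxymethyl group in place of the ester.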